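The source may hold more compounds than are shown below. What is called first, only, known or untested is meant among the compounds shown, and "the series" means these compounds.

Compound 2 `COc1ccc(S(=O)(=O)Nc2ccc(-c3nc4ccccc4o3)cc2)cc1` is a sulfonamide built on the same core as compound 1 `O=S(=O)(Nc1ccc(-c2nc3ccccc3o2)cc1)c1cccs1` and, with a different attachment, compound 3 `Cc1ccccc1S(=O)(=O)Nc1ccc2oc(-c3ccccc3)nc2c1`. In an ADME assay on HEK293 cells (Homo sapiens) for cytotoxicity, read by resazurin assay, with a stated time of 48 h (a lower number here means that less compound is tolerated, a higher number that more compound is tolerated), compound 2 gives > 100000 nM, which is a limit of the assay rather than a number. Compound 1 gives > 100000 nM in this assay, again a limit. Going by the values given here, compound 3 gives 57000 nM in this assay and is the only compound with a numerical value. The step that the two limits leave unreadable from compound 1 to compound 2 therefore cannot be read, because both of its ends sit at the limit of > 100000 nM in this assay, at which 2 of the 3 values shown sit. Compound 2 thus stands at the well-tolerated edge of what has been measured, with compound 1 at the same limit and compound 3 somewhat below it.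

Compound 4 `O=S(=O)(Nc1ccc(-c2nc3ccccc3o2)cc1)c1cccc(Cl)c1` differs from compound 2 in one place: 3-chlorophenyl in place of 4-methoxyphenyl on a sulfonyl sulfur. Among the compounds with values here, no measured step bears directly on this change; the only step, from compound 1 to compound 2, is unreadable, and compound 3 carries a different change at a different position of the core. In this assay compound 4 is expected to land near 90000 nM, with a range from 40000 nM to 200000 nM. The step of an at least 1.1-fold lower number from compound 2 to compound 4 (0.04 log units; that floor lies within the scatter) is expected to be small or again not readable, since compound 4 may itself reach only the limit.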

Compound 4, half-maximal cytotoxic concentration: > 100000 nM
Compound 4 ended at the assay's limit; the forecaster's own chance of this, stated with the estimate: 50%; middle value at least 1.1-fold (0.04 log units) from the limit.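

In this assay compound 4 gives > 100000 nM, which is a limit of the assay. The steps linking compound 4 to compound 2 and to compound 1 therefore cannot be read, because all three compounds sit at the same limit: the limit of > 100000 nM in this assay, at which 3 of the 4 values shown sit.

The compounds shown leave open how far compound 1, compound 2 and compound 4 actually differ in how well they are tolerated.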